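Swapping chloro for methyl on a fused benzimidazole core

The source may hold more compounds than are shown below. What is called first, only, known or untested is meant among the compounds shown, and "the series" means these compounds.

Measured compounds:
Compound 1, `Cc1ccc2[nH]c(-c3c(-c4ccc(F)cc4)nc4sc(C)nn34)nc2c1`: 7700 nM
Compound 2, `Cc1nn2c(-c3nc4cc(Cl)ccc4[nH]3)c(-c3ccc(F)cc3)nc2s1`: 4800 nM
Compound 3, `Cc1ccc(-c2nc3sc(C)nn3c2-c2nc3cc(Cl)ccc3[nH]2)cc1`: 5010 nM

All three were tested in a functional assay on A-375 cells (Homo sapiens) for antiproliferative activity, read by MTT assay; a lower number here means a stronger inhibitor, a higher number a weaker inhibitor. Compound 2 gives 4800 nM, compound 1 gives 7700 nM and compound 3 gives 5010 nM, so the three numbers sit close together.

Compound 1 and compound 2 share a core and differ by methyl in place of chloro on an aromatic carbon. The step of a 1.6-fold higher number from compound 2 to compound 1 (0.21 log units; within the scatter) is small. Compound 3 is built from compound 2 by methyl in place of fluoro on an aromatic carbon, and the step of a 1.0-fold higher number from compound 2 to compound 3 (0.02 log units; within the scatter) is also small.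

Compound 4, `Cc1ccc(-c2nc3sc(C)nn3c2-c2nc3cc(C)ccc3[nH]2)cc1`, has not been measured. It is made from compound 3 by methyl in place of chloro on an aromatic carbon, the same change that turns compound 2 into compound 1, at a place described in the same words. That earlier step was a 1.6-fold higher number from compound 2 to compound 1 (0.21 log units; within the scatter), so a step of similar size is expected here: a 1.4-fold higher number from compound 3 to compound 4 (0.15 log units; within the scatter) is the expected step. Among the measured compounds shown here, this rests on the single earlier example, compound 2 to compound 1, which also sits on the same core. For the measured compounds named here, with only one prior instance of the change, the expectation carries real uncertainty. Compound 4 is therefore estimated at 7000 nM, within a range from 3000 nM to 16000 nM.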

Compound 4, half-maximal inhibitory concentration: 6100 nM
Estimate against measurement, compound 4: 1.1-fold (0.06 log units) above; low and high end bracket the measured number.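

The new measurement adds two steps in this assay: a 1.2-fold higher number from compound 3 to compound 4 (0.09 log units; within the scatter) for methyl in place of chloro, and a 1.3-fold lower number from compound 1 to compound 4 (0.10 log units; within the scatter) for methyl in place of fluoro. Comparing the same swap in two different molecular settings is a simple test of whether its effect carries over, and for methyl in place of chloro the two cases agree as closely as repeat measurements would allow: the same change on two cores in this assay, a 1.6-fold higher number (0.21 log units; within the scatter) from compound 2 to compound 1 and a 1.2-fold higher number (0.09 log units; within the scatter) from compound 3 to compound 4, 1.3-fold (0.12 log units) apart, within the scatter of two such steps The same holds for methyl in place of fluoro, but every step here is small enough to be ordinary measurement scatter, so the agreement shows only that these swaps gave no step that can be told apart from that scatter in these four compounds, not that a larger effect would transfer in the same way or that the result would hold on other cores: the same change on two cores in this assay, a 1.0-fold higher number (0.02 log units; within the scatter) from compound 2 to compound 3 and a 1.3-fold lower number (0.10 log units; within the scatter) from compound 1 to compound 4, 1.3-fold (0.12 log units) apart, within the scatter of two such steps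

The compounds shown leave open whether a group of a different kind in place of the chloro or the fluoro, such as an amine, a carboxylic acid or a longer chain, would give a step beyond the scatter. If one did, it would remain to be seen whether that step stayed the same size from one core to the other.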